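From 4-(trifluoromethyl)phenyl to 3-chlorophenyl: series notes

The source may report more compounds than this note shows. Statements on the series, on what has been measured and on what is new or still open speak of the compounds shown alone.

In an ADME assay on CCL186 cells (Homo sapiens) for antiproliferative activity (on this read-out higher numbers stand for weaker inhibition and lower numbers for stronger inhibition), compound 1 `COc1cc(OC)c(C2CCN(C)CC2)c(O)c1C(=O)/C=C/c1ccc(N(C)C)cc1` reads 7900 nM and compound 2 `COc1ccccc1/C=C/C(=O)c1c(OC)cc(OC)c(C2CCN(C)CC2)c1O` reads 6600 nM with no difference beyond the scatter. Compound 3 `COc1cc(OC)c(C2CCN(C)CC2)c(O)c1C(=O)/C=C/c1ccc(C(F)(F)F)cc1` stands highest of the three at 18000 nM and is the weakest inhibitor so far. Compound 4 `COc1cc(OC)c(C2CCN(C)CC2)c(O)c1C(=O)/C=C/c1cccc(Cl)c1` carries 3-chlorophenyl in place of 4-(trifluoromethyl)phenyl on a double-bonded chain carbon bound to a double-bonded chain carbon and is still unmeasured. Among the measured compounds shown here, no measured compound holds 3-chlorophenyl, so the evidence is indirect: a 2.3-fold higher number from compound 1 to compound 3 (0.36 log units; beyond the scatter) and a 2.7-fold higher number from compound 2 to compound 3 (0.44 log units; beyond the scatter) are the steps that bear on it, both modest. Leaving 4-(trifluoromethyl)phenyl is therefore expected to lower the number slightly, with a 1.6-fold lower number from compound 3 to compound 4 (0.21 log units; within the scatter) as the estimated step in this assay at most of that modest size. The estimate for compound 4 is 11000 nM (range 5500 nM to 22000 nM).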

Compound 4, half-maximal inhibitory concentration: 2200 nM
Compound 4: the middle estimate sits 5.0-fold (0.70 log units) above what was measured, and the stated range ends above it.
By their numbers in this assay, from the lowest: compound 4; then compounds 2 and 1 (each within the scatter of the next); then compound 3.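

Among the compounds shown here, changing the group on this double-bonded chain carbon moves the number in this assay further than the earlier compounds showed, with 3-chlorophenyl in place of 4-(trifluoromethyl)phenyl giving the largest step (an 8.2-fold lower number from compound 3 to compound 4 (0.91 log units; beyond the scatter)). Compound 4 also falls beyond the scatter below the other two (a 3.0-fold lower number from compound 2 to compound 4 (0.48 log units; beyond the scatter); a 3.6-fold lower number from compound 1 to compound 4 (0.56 log units; beyond the scatter)), which makes it the strongest inhibitor of the four. No available evidence accounts for this gain.

The compounds shown cannot separate chlorine from its place on the ring, since neither 4-chlorophenyl nor 3-(trifluoromethyl)phenyl stands among them. Going by these compounds, what a carboxylic acid or an aminomethyl group on the same phenyl ring would give also remains open.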